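A few compounds are considered here, and "the series" means these few. Any claim that something is new, unique, unknown or untested is made for them only; others in the source may bear on it.

Three compounds have so far been measured in an assay on isolated protein for inhibition of lysosomal alpha-glucosidase (Homo sapiens), read by fluorescence, with stated times of 5 min and 45 min; a higher number here means a weaker inhibitor, a lower number a stronger inhibitor:

compound 1, `O=C1Cc2cc(S(=O)(=O)N3CCN(c4ccc(O)cc4)CC3)ccc2N1`, gives 1880 nM;
compound 2, `N#Cc1ccc(N2CCN(S(=O)(=O)c3ccc4c(c3)CC(=O)N4)CC2)cc1`, gives 2910 nM;
compound 3, `O=C1Cc2cc(S(=O)(=O)N3CCN(c4ccc([N+](=O)[O-])cc4)CC3)ccc2N1`, gives 3660 nM.

Compound 3 has the highest of the three numbers, but its distance to the others is small: the step of a 1.3-fold higher number from compound 2 to compound 3 (0.10 log units; within the scatter) and the step of a 1.9-fold higher number from compound 1 to compound 3 (0.29 log units; within the scatter) both lie within the scatter, so the three compounds are not separated by this assay. All three share one core and differ only in the group on the phenyl carbon named in the change below.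

Compound 4, `O=C1Cc2cc(S(=O)(=O)N3CCN(c4ccc(Cl)cc4)CC3)ccc2N1`, has not yet been measured. It differs from compound 3 in one place: chloro in place of nitro on an aromatic carbon. The measured steps that bear on this are the three exchanges at the same place, a 1.5-fold higher number from compound 1 to compound 2 (0.19 log units; within the scatter), a 1.9-fold higher number from compound 1 to compound 3 (0.29 log units; within the scatter) and a 1.3-fold higher number from compound 2 to compound 3 (0.10 log units; within the scatter), none of which moved the number beyond the scatter. The expectation is therefore that compound 4 also stays close to compound 3, with an estimated step of a 1.5-fold lower number from compound 3 to compound 4 (0.17 log units; within the scatter) that does not exceed the scatter. The estimated value for compound 4 in this assay is 2500 nM, with a range from 1200 nM to 5500 nM.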

Compound 4, half-maximal inhibitory concentration: 94300 nM
The estimate for compound 4 lay 38-fold (1.58 log units) below the measured number; measured number above the stated range.
By their numbers in this assay, from the lowest: compounds 1, 2 and 3 (each within the scatter of the next); then compound 4.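

The earlier exchanges at this aromatic carbon had all stayed within the scatter in this assay, so the position could have seemed indifferent to its substituent, but chloro shows that it is not, with a 26-fold higher number from compound 3 to compound 4 (1.41 log units; beyond the scatter), a 32-fold higher number from compound 2 to compound 4 (1.51 log units; beyond the scatter) and a 50-fold higher number from compound 1 to compound 4 (1.70 log units; beyond the scatter), which makes compound 4 the weakest inhibitor of the four. The exchange of nitro for chloro replaces a group that has hydrogen-bond acceptors with one that has none, but this is only a count taken from the two structures, and one compound cannot show that it matters. Nothing available here explains why chloro stands so far apart from hydroxy, cyano and nitro.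

Going by these compounds, it remains open whether this large step belongs to chloro alone or would also appear with fluoro, bromo, methyl or methoxy at the same carbon. On these data alone, it is equally open whether an amine or a carboxylic acid there would stay with compounds 1, 2 and 3 or move towards compound 4.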